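The source may report more compounds than this note shows. Statements on the series, on what has been measured and on what is new or still open speak of the compounds shown alone.

The three measured compounds and their values in a functional assay on SGC-7901 cells (Homo sapiens) for cytotoxicity, read by MTT assay, with a stated time of 48 h; on this read-out higher numbers stand for weaker inhibition and lower numbers for stronger inhibition:

compound 1, `O=C(CSc1ccccc1)N1N=C(c2cc3ccccc3oc2=O)C[C@@H]1c1ccccc1`, with 20300 nM
compound 2, `CC1=NN(C(=O)CSc2ccccc2)[C@@H](c2cc(Br)cc(Br)c2O)C1`, with 24100 nM
compound 3, `O=C(CSc1ccc(Br)cc1)N1N=C(c2cc3ccccc3oc2=O)C[C@@H]1c1ccccc1`, with 14300 nM

Compound 1 and compound 3 share one core, and compound 3 carries one change on it: bromo in place of hydrogen on an aromatic carbon. That change made a step of a 1.4-fold lower number from compound 1 to compound 3 (0.15 log units; within the scatter), so the two values are not separated in any reliable way. Compound 2 is built on a different core; the difference between the two cores is not broken down here. Its value lies near those of compound 1 and compound 3, and all three numbers sit within the usual scatter of one another, so none of them can be called stronger or weaker than the others.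

Compound 4, `CC1=NN(C(=O)CSc2ccc(Br)cc2)[C@@H](c2cc(Br)cc(Br)c2O)C1`, has not yet been measured. It stands to compound 2 as compound 3 stands to compound 1, with the same change: bromo in place of hydrogen on an aromatic carbon. Among the compounds with values here, since the "place" of the change is the same in both pairs, the only guide is the step seen on the other core. Compound 4 is therefore expected to give a step of about a 1.3-fold lower number from compound 2 to compound 4 (0.13 log units; within the scatter) in this assay, resting on compound 1 and compound 3 showing a 1.4-fold lower number from compound 1 to compound 3 (0.15 log units; within the scatter). For compound 4 the estimated value is 18000 nM, with a likely range from 8000 nM to 40000 nM.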

Compound 4, half-maximal inhibitory concentration: 8210 nM
Compound 4: middle estimate off by 2.2-fold (0.34 log units), on the high side, within the range that was stated.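

In this assay, bromo in place of hydrogen on an aromatic carbon now gives a step that stands clear of the usual scatter, a 2.9-fold lower number from compound 2 to compound 4 (0.47 log units; beyond the scatter). Set beside the same change on the core of compound 1, this step cannot be told apart from the earlier one, even though only one of the two lies beyond the scatter on its own: the same change on two cores in this assay, a 1.4-fold lower number (0.15 log units; within the scatter) from compound 1 to compound 3 and a 2.9-fold lower number (0.47 log units; beyond the scatter) from compound 2 to compound 4, 2.1-fold (0.32 log units) apart, within the scatter of two such steps. This means the four compounds fit with the change carrying over from one core to the other, but two pairs do not prove that its size is the same on both cores, and they say nothing about how it would behave on any further core.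

The compounds shown hold only hydrogen or bromo at this spot, so they leave open whether chloro, methyl or methoxy in the same place, para to a large group, would give a step of similar size on either core. They also leave open what an amine or a carboxylic acid would do at that spot, and whether a longer chain in place of the phenyl group would keep these values.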